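This account rests on a few compounds, and the source may have more. Where it says the series, first, only, none or still open, it means among the compounds named here.

In a functional assay on DU-145 cells (Homo sapiens) for inhibition, read by trypan blue exclusion, with a stated time of 96 h (a lower number here means a stronger inhibitor of growth, a higher number a weaker inhibitor of growth), three compounds have been measured:

Compound 1 `CSc1ccc(/C=C(\C(=O)c2ccc(Br)cc2)S(=O)(=O)Cc2ccc(F)cc2)cc1`: 50000 nM
Compound 2 `Cc1ccc(C)c(/C=C(\C(=O)c2ccc(Br)cc2)S(=O)(=O)Cc2ccc(F)cc2)c1`: 1000 nM
Compound 3 `O=C(/C(=C\c1ccc(O)cc1)S(=O)(=O)Cc1ccc(F)cc1)c1ccc(Br)cc1`: 10000 nM

Compound 3 holds the middle of these three numbers, with compound 1 higher and compound 2 lower. Compound 4 `CN(C)c1ccc(/C=C(\C(=O)c2ccc(Br)cc2)S(=O)(=O)Cc2ccc(F)cc2)cc1` has not been measured yet. It keeps the shared core and changes one group: dimethylamino in place of hydroxy on an aromatic carbon, para to a large group.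

Within the data shown here, no measured step makes this exact swap, so the nearest evidence comes from changes in the same part of the molecule. Replacing methylsulfanyl with hydroxy gave a 5.0-fold lower number from compound 1 to compound 3 (0.70 log units; beyond the scatter). The steps involving 2,5-dimethylphenyl were a 50-fold lower number from compound 1 to compound 2 (1.70 log units; beyond the scatter) and a 10-fold higher number from compound 2 to compound 3 (1.00 log units; beyond the scatter). Compound 4 keeps a single group on that ring, as compound 1 and compound 3 do, but the data give no clear direction for this swap. The estimated change is therefore none beyond the scatter: no change at the digits printed from compound 3 to compound 4 (within the scatter). Compound 4 is expected near 10000 nM, with an estimated range from 1500 nM to 50000 nM.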

Compound 4, concentration for 50% growth inhibition: 50000 nM
Compound 4: middle estimate off by 5.0-fold (0.70 log units), on the low side; the range from low to high includes it.
By their numbers in this assay, from the lowest: compound 2; then compound 3; then compounds 1 and 4 (each within the scatter of the next).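

In this assay, among these compounds, the single group on this ring matters: dimethylamino in place of hydroxy, para to a large group, gives a 5.0-fold higher number from compound 3 to compound 4 (0.70 log units; beyond the scatter). Two quite different replacements for hydroxy end up level, as dimethylamino in place of methylsulfanyl gives no change at the digits printed from compound 1 to compound 4 (within the scatter), so among the three compounds with one group on this ring, compound 3 has the lowest number. None of the three approaches the 2,5-dimethylphenyl ring, and the change from that ring to 4-(dimethylamino)phenyl gives a 50-fold higher number from compound 2 to compound 4 (1.70 log units; beyond the scatter).

Nothing available here accounts for these differences. As far as these compounds go, it remains open whether a plain amine or a methoxy group in the same place would match hydroxy, and whether a single methyl on the ring would be enough to reach the low number of compound 2.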